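A Methyl Added to the Ethylphenyl Arm

The source may report more compounds than this note shows. Statements on the series, on what has been measured and on what is new or still open speak of the compounds shown alone.

Compound 1 `Cc1cc(C)cc(-n2nncc2CN2C(=O)C3(C(C#N)=C(N)Oc4c3c3nc5ccccc5nc3c3ccccc43)c3ccccc32)c1`: > 50000 nM
Compound 2 `CCc1ccccc1-n1nncc1CN1C(=O)C2(C(C#N)=C(N)Oc3c(N)cc4nc5ccccc5nc4c32)c2ccccc21`: 10300 nM

Of the compounds shown here, two have been tested in a functional assay on HCT-116 cells (Homo sapiens) for antiproliferative activity, read by MTT assay, with a stated time of 48 h; a lower number here means a stronger inhibitor, a higher number a weaker inhibitor. For compound 1 the result is not a number but a limit of the assay, > 50000 nM, and it is this case that the limit of > 50000 nM in this assay, at which 1 of the 2 values shown sits, describes. Going by the values given here, compound 2 gives 10300 nM in this assay, and this is the only numerical value so far. The result for compound 1 is only a limit of the assay. Compound 2 therefore cannot be ranked against anything.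

Compound 3 `CCc1cccc(C)c1-n1nncc1CN1C(=O)C2(C(C#N)=C(N)Oc3c(N)cc4nc5ccccc5nc4c32)c2ccccc21` differs from compound 2 in one place: methyl in place of hydrogen on an aromatic carbon. The methyl enters ortho to a large group and meta to the ethyl group, so that the 2-ethylphenyl becomes a 2-ethyl-6-methylphenyl. Among the compounds with values here, no pair of measured compounds shows the effect of such a change here, so there is nothing to lean on.

A single methyl on an aromatic carbon is a small addition, and the step of a 1.1-fold lower number from compound 2 to compound 3 (0.06 log units; within the scatter) is expected to stay within the usual scatter, in no firm direction. Compound 3 is therefore estimated to give about 9000 nM in this assay, with a likely range from 3000 nM to 30000 nM.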

Compound 3, half-maximal inhibitory concentration: > 50000 nM
Compound 3 gave a limit, no number; the forecaster's own chance of this, stated with the estimate: 15%; middle value at least 5.5-fold (0.74 log units) from the limit.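

A methyl at this place, ortho to a large group, is not a neutral addition: in this assay it gives an at least 4.8-fold higher number from compound 2 to compound 3 (0.68 log units; beyond the scatter) and moves the result out of the range where the assay gives a number. Going by these compounds alone, the earlier compounds offered no comparison, so this is the first measured sign that the aryl group on the triazole can matter to activity, even when the change is a single carbon, here from 2-ethylphenyl to 2-ethyl-6-methylphenyl. The result for compound 3 is a limit of the assay and not a number, and it is not alone in that: the limit of > 50000 nM in this assay, at which 2 of the 3 values shown sit.

The true size of the loss therefore stays unknown, and nothing here shows why one added methyl has this effect. Still open, as far as these compounds go, is whether a different group at the same place, such as a fluorine atom, a methoxy group or an amine, would keep the activity of compound 2, and whether a methyl placed elsewhere on the ring, meta or para to the ethyl group, would give the same result.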